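Replacing the indolyl amine in a fluorinated enaminone series

This account rests on a few compounds, and the source may have more. Where it says the series, first, only, none or still open, it means among the compounds named here.

Compounds measured so far:
Compound 1, `O=C(/C=C\Nc1ccc(F)cc1)c1nc(-c2ccc(F)cc2)n2ccccc12`: 25100 nM
Compound 2, `COc1ccc(N/C=C\C(=O)c2nc(-c3ccc(C(F)(F)F)cc3)n3ccccc23)cc1OC`: > 30000 nM
Compound 3, `O=C(/C=C\Nc1ccc2[nH]ccc2c1)c1nc(-c2ccc(C(F)(F)F)cc2)n2ccccc12`: 1180 nM

In a functional assay on MDA-MB-231 cells (Homo sapiens) for cytotoxicity, read by MTT assay, with a stated time of 48 h (a lower number here means a stronger inhibitor, a higher number a weaker inhibitor), compound 3 gives 1180 nM, the lowest of the two numbers recorded. Its nearest neighbour is compound 1, which gives 25100 nM. For compound 2 this assay reports only a limit, > 30000 nM, and no number (the limit of > 30000 nM in this assay, at which 1 of the 3 values shown sits).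

Among the measured compounds shown here, the only measured step that changes the aryl group on the amine nitrogen is an at least 25-fold lower number from compound 2 to compound 3 (1.40 log units; beyond the scatter). That step shows the indolyl group set against a substituted phenyl group and the numbers moving strongly in its favour.

Compound 4, `O=C(/C=C\Nc1ccc(F)cc1)c1nc(-c2ccc(C(F)(F)F)cc2)n2ccccc12`, has not been measured. It differs from compound 3 by 4-fluorophenyl in place of 1H-indol-5-yl on an amine nitrogen. Compound 1 carries the same 4-fluorophenyl group on its amine nitrogen, though on a different core, and gives 25100 nM. Taking the measured step with the indolyl group and the value of compound 1 together, compound 4 is expected to move to a clearly higher number, by about a 15-fold higher number from compound 3 to compound 4 (1.18 log units; beyond the scatter). Compound 4 is therefore estimated at 18000 nM, with a likely range from 5000 nM to 30000 nM.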

Compound 4, half-maximal inhibitory concentration: > 30000 nM
Compound 4: only a limit was reported; the forecaster's own chance of this, stated with the estimate: 25%; middle value at least 1.6-fold (0.22 log units) from the limit.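

In this assay, 4-fluorophenyl in place of 1H-indol-5-yl on the amine nitrogen gives an at least 25-fold higher number from compound 3 to compound 4 (1.40 log units; beyond the scatter), with the rest of the molecule unchanged, so the indolyl group now stands out against two different phenyl groups rather than one. Trifluoromethyl in place of fluoro on an aromatic carbon gives an at least 1.1-fold higher number from compound 1 to compound 4 (0.07 log units; that floor lies within the scatter), a floor within the scatter, so this pair shows no gain from trifluoromethyl when the amine nitrogen carries 4-fluorophenyl. Compound 4 carries only a limit, as compound 2 does, and the step between them cannot be read: the limit of > 30000 nM in this assay, at which 2 of the 4 values shown sit.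

As far as these compounds go, how far either phenyl compound lies past that limit remains unknown, so the full size of the indolyl advantage stays open. From the compounds shown here alone, it is also open whether another two-ring group without the ring nitrogen, such as naphthyl, would give a number like that of compound 3, or whether the 1H-indol-5-yl group keeps its advantage with fluoro in place of trifluoromethyl on the aromatic carbon.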